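The compounds below may be only part of what the source reports. "The series", "measured", "known", "first", "only" and "open" are said of these compounds alone.

In an assay on cells for displacement of a labelled ligand from adenosine receptor A1 (Homo sapiens), read by scintillation counting and radioligand binding, with a stated time of 60 min, tested at 10 uM (on this read-out higher numbers stand for more inhibition at the one concentration tested (going by the name of the read-out) and lower numbers for less inhibition), compound 1 `Cn1cnc2c(N3CCCCC3)nc(-c3ccccc3O)nc21` gives 50.5%. Compound 3 `CN1CCN(c2nc(-c3ccccc3O)nc3c2ncn3C)CC1` reaches only a limit of the assay, namely > 80%. The change 4-methylpiperazin-1-yl in place of piperidin-1-yl on an aromatic carbon therefore produced a number at least 29.5 percentage points higher from compound 1 to compound 3 (beyond the scatter), and the true size of this step is known only as a lower bound because of the limit of > 80% in this assay, at which 2 of the 3 values shown sit. Compound 2 `Oc1cccc(-c2nc(N3CCCCC3)c3nc[nH]c3n2)c1` likewise reaches only a limit of the assay, > 80%. How the core of compound 2 differs from the core of compound 1 is not broken down here.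

Compound 4 `CN1CCN(c2nc(-c3cccc(O)c3)nc3[nH]cnc23)CC1` has not yet been measured. It is related to compound 2 by 4-methylpiperazin-1-yl in place of piperidin-1-yl on an aromatic carbon. For the measured compounds named here, this is the same kind of change as the one leading from compound 1 to compound 3, although the surroundings differ: here the place is meta to a 3-hydroxyphenyl group, whereas before it was meta to a 2-hydroxyphenyl group. Because the earlier change gave a number at least 29.5 percentage points higher from compound 1 to compound 3 (beyond the scatter), the step from compound 2 to compound 4 is expected to be a step that the limit leaves unreadable from compound 2 to compound 4, an apparent step only, as compound 2 already sits at a limit. Compound 4 is thus estimated to give about 86%, within a range from 72% to 96%.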

Compound 4, a percentage reported as inhibition, at one concentration (the size of the read-out at that concentration, not a potency): > 80%
Compound 4 ended at the assay's limit; the forecaster's own chance of this, stated with the estimate: 80%; the middle value lies beyond the limit too.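

In this assay compound 4 gives > 80%, which is a limit of the assay. Compound 2 also sits at a limit, so no step from compound 2 to compound 4 can be read, because neither has an exact value: the limit of > 80% in this assay, at which 3 of the 4 values shown sit.

The compounds shown leave open how much 4-methylpiperazin-1-yl in place of piperidin-1-yl changes inhibition alongside a 3-hydroxyphenyl group.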